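The compounds below may be only part of what the source reports. "The series", "measured", "known", "first", "only" and "open" are said of these compounds alone.

Among the measured compounds shown here, compound 1 `CCOC(=O)c1cnc(-c2ccccc2)nc1NN1C(=O)C=C(C)C1=O` is one of two compounds measured in a functional assay on Jurkat cells for inhibition of nuclear factor NF-kappa-B complex (Homo sapiens); on this read-out lower numbers stand for stronger inhibition and higher numbers for weaker inhibition. In this assay compound 1 gives 100 nM, the lowest of the two numbers. For the measured compounds named here, its only measured neighbour is compound 2 `CCOC(=O)c1cnc(S(=O)(=O)c2ccccc2)nc1NN1C(=O)C=C(C)C1=O`, which in this assay gives 10000 nM. Going by the values given here, the one step between them, a 100-fold higher number from compound 1 to compound 2 (2.00 log units; beyond the scatter), replaces a phenyl group with a phenylsulfonyl group on a carbon of the shared core.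

Compound 3 `CCOC(=O)c1cnc(-c2ccccc2)nc1N(C(C)=O)N1C(=O)C=C(C)C1=O` has not been measured. It differs from compound 1 in a single place: acetyl in place of hydrogen on a nitrogen on an aromatic ring. This change sits on the nitrogen that links the core to the ring-shaped amide, a site the measured step from compound 1 to compound 2 does not touch. The measured step therefore shows how sensitive the series can be to a single replacement, but it gives no direct guide for covering that hydrogen with an acetyl group. Among the compounds with values here, because compound 1 gives 100 nM and no measured step touches this nitrogen, the expectation for compound 3 remains uncertain, with a modest weakening expected as the middle case, a 3.0-fold higher number from compound 1 to compound 3 (0.48 log units; beyond the scatter). In this assay compound 3 is expected to give about 300 nM, with a range from 60 nM to 2500 nM.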

Compound 3, half-maximal inhibitory concentration: 4000 nM
Estimate against measurement, compound 3: 13-fold (1.12 log units) below; measured number above the stated range.
By their numbers in this assay, from the lowest: compound 1; then compound 3; then compound 2.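

In this assay, acetyl in place of hydrogen on this nitrogen gives a 40-fold higher number from compound 1 to compound 3 (1.60 log units; beyond the scatter), a large step towards weaker inhibition. This nitrogen, whose other neighbours are an amide-type nitrogen in a ring and an aromatic carbon, is therefore a sensitive place in the series, and the large step from phenylsulfonyl on an aromatic carbon is no longer the only one on record. Nothing shown explains why the acetyl step is so large.

Since only one replacement at this nitrogen is shown, it remains open whether the weaker inhibition goes with acetyl in particular or with replacing the hydrogen by any group at all. A methyl group or a longer acyl chain such as butanoyl on the same nitrogen would help to tell these two readings apart, and neither of them appears among the compounds shown.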